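This account rests on a few compounds, and the source may have more. Where it says the series, first, only, none or still open, it means among the compounds named here.

Working notes on the series. Three compounds sharing one core have been run in a functional assay on the whole organism (Ear) for inhibition, with Mus musculus as the target, at a dose of 40 mg/kg by the oral route (a higher number here means more inhibition at the dose given (going by the name of the read-out), a lower number less inhibition), so far, each differing only in the group on the amide-type nitrogen. Compound 1 `CNC(=O)c1cc(-c2ccc(F)cc2F)ccc1OC(C)=O` gives 48.8% in this assay. Compound 2 `CC(=O)Oc1ccc(-c2ccc(F)cc2F)cc1C(=O)NC1CCCCC1` gives 0%. Compound 3 `CC(=O)Oc1ccc(-c2ccc(F)cc2F)cc1C(=O)Nc1ccccc1C` gives 19.6%, which places compound 3 second highest of the three numbers, between compound 1 above it and compound 2 below it, both gaps beyond the scatter.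

The measured steps are a number 48.8 percentage points lower from compound 1 to compound 2 (beyond the scatter), a number 29.2 percentage points lower from compound 1 to compound 3 (beyond the scatter) and a number 19.6 percentage points higher from compound 2 to compound 3 (beyond the scatter). Each of them exchanges the whole group on the amide-type nitrogen, and the two that involve compound 3 were modest.

Compound 4 `CC(=O)Oc1ccc(-c2ccc(F)cc2F)cc1C(=O)Nc1ccc(C)cc1` is the next step from compound 3: 4-methylphenyl in place of 2-methylphenyl on an amide-type nitrogen. Among the compounds with values here, no measured step keeps the aryl group and only shifts the methyl on it, so the bearing steps are those into compound 3, which were modest, and they give no direction for this finer change. The expectation is therefore a step from compound 3 to compound 4 of a number 2.4 percentage points higher from compound 3 to compound 4 (within the scatter) in this assay, that is, a change likely within the scatter in either direction. Compound 4 is accordingly estimated at 22%, with a range from 0% to 45%.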

Compound 4, a percentage reported as inhibition, in the whole organism at one dose (the size of the read-out at that dose, not a potency): 36.4%
Estimate against measurement, compound 4: 14.4 percentage points below; measured number inside the range.
By their numbers in this assay, from the lowest: compound 2; then compound 3; then compound 4; then compound 1.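

In this assay, the step from the 2-methylphenyl group to the 4-methylphenyl group is a number 16.8 percentage points higher from compound 3 to compound 4 (beyond the scatter), so with the same atoms in both compounds, this position on the amide-type nitrogen responds to where the methyl sits on the aryl ring and not only to which kind of group is present. The lower number of compound 3 therefore cannot be read as applying to aryl groups in general: the remaining steps are a number 12.4 percentage points lower from compound 1 to compound 4 (beyond the scatter) and a number 36.4 percentage points higher from compound 2 to compound 4 (beyond the scatter), which puts the 4-methylphenyl group below the methyl group of compound 1 and above the cyclohexyl group of compound 2. No measured information on any property of these groups bears on why the methyl shift alters the number.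

The compounds shown leave open whether an unsubstituted phenyl, 3-methylphenyl or 4-chlorophenyl group would continue this trend on the aryl ring, and whether a short chain such as ethyl would match or pass the methyl group of compound 1. On these data alone, each number is also the size of the read-out at one oral dose, so the order of the four compounds at other doses remains open.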